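This account rests on a few compounds, and the source may have more. Where it says the series, first, only, none or still open, it means among the compounds named here.

Of the compounds shown here, two have been measured in an assay on isolated protein for inhibition of coagulation factor X (Oryctolagus cuniculus), tested at 1 uM (on this read-out lower numbers stand for less inhibition and higher numbers for more inhibition at the one concentration tested (going by the name of the read-out)), so far. Compound 1 `O=C1[C@@H](NS(=O)(=O)c2cc3c(Cl)nccc3s2)CCN1Cc1cc2c[nH]ccc-2n1` gives 35% in this assay. Compound 2 `CC(C)(C)c1ccc(S(=O)(=O)N[C@H]2CCN(Cc3cc4[nH]cccc-4n3)C2=O)cc1` gives 22% in this assay, the lowest of the two numbers, and it sits a gap beyond the usual scatter below compound 1. The two measured compounds differ in more than one place, so no single step can be read from them; only their two values can be compared.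

Compound 3 `CC(C)(C)c1ccc(S(=O)(=O)N[C@H]2CCN(Cc3cc4c[nH]ccc-4n3)C2=O)cc1` has not yet been measured. It differs from compound 2 in one place: a group of 9 heavy atoms (7 carbon, 2 nitrogen; one five-membered aromatic ring with 1 hetero atom, one six-membered aromatic ring with 1 hetero atom) in place of a group of 9 heavy atoms (7 carbon, 2 nitrogen; one five-membered aromatic ring with 1 hetero atom, one six-membered aromatic ring with 1 hetero atom), on a saturated chain carbon bound to an amide-type nitrogen in a ring. The group that enters compound 3 is the same group that compound 1 carries on its saturated chain carbon bound to the amide-type nitrogen in the ring, while the rest of compound 3 is that of compound 2. Within the data shown here, no measured pair shows this change on its own, so its effect is unknown. The step from compound 2 to compound 3 is expected to be small, a number 4 percentage points higher from compound 2 to compound 3 (within the scatter), within the scatter, with no clear direction. Compound 3 is therefore estimated at 26%, in a range from 10% to 45%.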

Compound 3, a percentage reported as inhibition, at one concentration (the size of the read-out at that concentration, not a potency): 14%
Estimate against measurement, compound 3: 12 percentage points above; low and high end bracket the measured number.
By their numbers in this assay, from the lowest: compounds 3 and 2 (each within the scatter of the next); then compound 1.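

In this assay, rejoining the same atoms of the two-ring group on the saturated chain carbon bound to an amide-type nitrogen in a ring gives a number 8 percentage points lower from compound 2 to compound 3 (within the scatter), so with the shared sulfonamide part held constant, this position does not separate the two forms of the group. The change on the sulfonyl sulfur, where the group of carbon only replaces the group holding nitrogen, sulfur and chlorine, gives a number 21 percentage points lower from compound 1 to compound 3 (beyond the scatter), and of the two single-place steps now available, only this one goes beyond the scatter. Nothing at hand gives a reason for either step.

It remains open whether the two forms of the two-ring group would also stay within the scatter of each other with the chlorine-bearing group on the sulfonyl sulfur, since only one pairing with that group is shown. Also open, on these data alone, is how much of the step on the sulfonyl sulfur belongs to the chlorine, which a matching group with hydrogen in its place could test, and what a simple phenyl or a methyl group there would give.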